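The source may hold more compounds than are shown below. What is called first, only, known or untested is meant among the compounds shown, and "the series" means these compounds.

Working notes on the series in a functional assay, read by spectrophotometry, tested at 100 uM (on this read-out higher numbers stand for weaker inhibition and lower numbers for stronger inhibition), follow. Compound 1 (`O=C(/C=C/c1cccc2ccccc12)c1cccc(NC(=O)c2cc(-c3ccncc3)n[nH]2)c1`) gives 72100 nM in this read-out, and compound 2 (`O=C(/C=C/c1ccc(Cl)cc1Cl)c1cccc(NC(=O)c2cc(-c3ccncc3)n[nH]2)c1`) gives 80900 nM on the same scale. Going by the values given here, compound 2 stands level with compound 1, the only other number available, and the step between them (a 1.1-fold higher number from compound 1 to compound 2 (0.05 log units; within the scatter)) lies within the scatter.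

Compound 3 (`CC(C)c1ccc(/C=C/C(=O)c2cccc(NC(=O)c3cc(-c4ccncc4)n[nH]3)c2)cc1`) is still unmeasured and keeps the shared core. Its change from compound 2 sits on a double-bonded chain carbon bound to a double-bonded chain carbon (4-isopropylphenyl in place of 2,4-dichlorophenyl on a double-bonded chain carbon bound to a double-bonded chain carbon). Among the compounds with values here, the one measured step at that place is the exchange of naphthalen-1-yl for 2,4-dichlorophenyl (a 1.1-fold higher number from compound 1 to compound 2 (0.05 log units; within the scatter)), and it did not move the number beyond the scatter. Within the data shown here, no measured compound carries 4-isopropylphenyl, so this single step is thin support.

In this assay no step beyond the scatter is therefore expected, and the estimated step (a 1.2-fold lower number from compound 2 to compound 3 (0.06 log units; within the scatter)) carries no firm direction. For compound 3 the expected value is 70000 nM as a working estimate, with an estimated range from 30000 nM to 125000 nM kept wide on this evidence.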

Compound 3, half-maximal inhibitory concentration: 60200 nM
The estimate for compound 3 lay 1.2-fold (0.07 log units) above the measured number, and the stated range covers the measured number.
By their numbers in this assay, from the lowest: compounds 3, 1 and 2 (each within the scatter of the next).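

The exchange of 2,4-dichlorophenyl for 4-isopropylphenyl on a double-bonded chain carbon bound to a double-bonded chain carbon stays within the scatter in this assay (a 1.3-fold lower number from compound 2 to compound 3 (0.13 log units; within the scatter)), and so does the exchange of naphthalen-1-yl for 4-isopropylphenyl (a 1.2-fold lower number from compound 1 to compound 3 (0.08 log units; within the scatter)). With the earlier step, this place now has three aryl groups that cannot be told apart on this read-out: a group of carbon only with an isopropyl substituent, a chlorine-bearing group and a fused naphthalen-1-yl group, where compounds 1 and 2 alone offered a single comparison. All three pairs within the series therefore give no order among these groups, and nothing available explains why the numbers remain together at this place.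

From the compounds shown here alone, whether a phenyl group carrying an amine or a carboxylic acid, or a saturated group such as cyclohexyl, would move the number beyond the scatter at this place remains open, since every group here is a carbon-ring aromatic without hydrogen-bond donors or acceptors. The shared core is unchanged throughout, so the compounds shown say nothing about how the number responds to changes elsewhere in the structure.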